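Aryl exchange at the carbon double-bonded to nitrogen

The compounds below may be only part of what the source reports. "The series", "measured", "known", "first", "only" and "open" are said of these compounds alone.

Compound 2 `COc1cccc(/C=N\NC(=O)c2oc3cccc(O)c3c2C)c1` carries a 3-methoxyphenyl group on the carbon with a double bond to nitrogen. In a functional assay on PC-3 cells (Homo sapiens) for inhibition (on this read-out lower numbers stand for stronger inhibition and higher numbers for weaker inhibition), compound 2 returns only a limit of the assay, >= 40000 nM. Compound 1 `Cc1c(C(=O)N/N=C\c2cccnc2)oc2cccc(O)c12`, with pyridin-3-yl in the same place, likewise gives only a limit in this assay, >= 40000 nM. The step that the two limits leave unreadable from compound 1 to compound 2 therefore cannot be read, and the limit of >= 40000 nM in this assay, at which 2 of the 2 values shown sit, is all the two values show. Compound 3 `Cc1c(C(=O)N/N=C\c2cc(Cl)ccc2O)oc2cccc(O)c12` differs from compound 2 by 5-chloro-2-hydroxyphenyl in place of 3-methoxyphenyl on a carbon with a double bond to nitrogen. Among the measured compounds shown here, no measured step bears on this change with a readable size; the sole comparison is unreadable, so no direction can be drawn from it. In this assay the step of a number no higher from compound 2 to compound 3 (the limit leaves the size open) is therefore expected to stay within the scatter, with a further limit the most likely outcome. The estimate for compound 3 in this assay is 40000 nM, with a range from 10000 nM to 100000 nM.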

Compound 3, half-maximal inhibitory concentration: 3120 nM
Compound 3: middle estimate off by 13-fold (1.11 log units), on the high side; measured number below the stated range.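

Among the compounds shown here, compound 3 gives the first true number for this position, on a carbon with a double bond to nitrogen. In this assay, 5-chloro-2-hydroxyphenyl in place of 3-methoxyphenyl gives an at least 12-fold lower number from compound 2 to compound 3 (1.10 log units; beyond the scatter), and in place of pyridin-3-yl it gives an at least 12-fold lower number from compound 1 to compound 3 (1.10 log units; beyond the scatter), so the aryl group at this position can shift the read-out, which the unreadable step between the two earlier compounds could not show. Both steps start from a limit of the assay and not from a number: the limit of >= 40000 nM in this assay, at which 2 of the 3 values shown sit.

Going by these compounds, whether the lower number goes with the hydroxy group, the chlorine or the two together stays open. Also open, on these data alone, is how this assay would read with an amine or a carboxylic acid in place of that hydroxy group.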